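A few compounds are considered here, and "the series" means these few. Any claim that something is new, unique, unknown or untested is made for them only; others in the source may bear on it.

Measured compounds in a functional assay on cells (Homo sapiens) for inhibition, read by MTT assay, with a stated time of 72 h; on this read-out lower numbers stand for stronger inhibition and higher numbers for weaker inhibition:
Compound 1, `CCOC(=O)Cn1ncc2c(Nc3ccc(NC(=O)c4ccccc4)cc3)ncnc21`, gives > 100 ug/mL, which is a limit of the assay.
Compound 2, `O=C(O)Cn1ncc2c(Nc3ccc(NS(=O)(=O)c4ccc(Br)cc4)cc3)ncnc21`, gives > 64 ug/mL, also a limit.
Compound 3, `O=C(O)Cn1ncc2c(Nc3ccc(NC(=O)c4ccccc4)cc3)ncnc21`, gives > 100 ug/mL, again a limit.

The cores of compound 2 and compound 3 differ by (4-bromophenyl)sulfonyl in place of benzoyl on a nitrogen on an aromatic ring, and the step that the two limits leave unreadable from compound 2 to compound 3 remains unreadable since both values sit at limits, the limit of > 64 ug/mL in this assay, at which 1 of the 3 values shown sits, and (the limit of > 100 ug/mL in this assay, at which 2 of the 3 values shown sit). The change from compound 3 to compound 1 is ethyl in place of hydrogen on an oxygen next to a carbonyl group; the step that the two limits leave unreadable from compound 3 to compound 1 is likewise unreadable since both values sit at the limit of > 100 ug/mL in this assay, at which 2 of the 3 values shown sit. Compound 4, `CCOC(=O)Cn1ncc2c(Nc3ccc(NS(=O)(=O)c4ccc(Br)cc4)cc3)ncnc21`, not yet measured, carries the same change on the core of compound 2: ethyl in place of hydrogen on an oxygen next to a carbonyl group. Among the measured compounds shown here, because the step that the two limits leave unreadable from compound 3 to compound 1, the only measured instance of this change, showed no readable movement, compound 4 is expected to stay at a limit as well, with an expected step that the limit leaves unreadable from compound 2 to compound 4. The estimate for compound 4 in this assay is 100 ug/mL, expected to fall between 30 ug/mL and 300 ug/mL.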

Compound 4, half-maximal inhibitory concentration: > 64 ug/mL
Compound 4: a limit, no number; the forecaster's own chance of this, stated with the estimate: 85%; the middle value is on the limit's open side.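

In this assay, among the compounds shown here, compound 4 gives > 64 ug/mL, a limit of the assay, so no step to compound 2 or compound 1 can be read. The compounds shown leave open whether ethyl in place of hydrogen, or the change between benzoyl and (4-bromophenyl)sulfonyl, shifts inhibition at all.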